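This account rests on a few compounds, and the source may have more. Where it says the series, first, only, none or still open, it means among the compounds named here.

Series notes in an ADME assay on Huh-7 cells (Homo sapiens) for cytotoxicity, read by a luciferase reporter and WST assay, with a stated time of 3 days; on this read-out higher numbers stand for lower toxicity in this test and lower numbers for higher toxicity in this test. Compound 1 `COc1ccc(-c2cc(NO)c(C(=O)Nc3ccc(C)cc3)c(=O)o2)cc1` reaches only the assay limit, > 20000 nM. Compound 2 `COc1ccc(-c2cc(NO)c(C(=O)NCCO)c(=O)o2)cc1` likewise gives only a limit, > 20000 nM. Compound 3 `COC(=O)CNC(=O)c1c(NO)cc(-c2ccc(F)cc2)oc1=O` also stops at the limit, > 20000 nM. Within the data shown here, the one measured step, a step that the two limits leave unreadable from compound 1 to compound 2, cannot be sized from two limits. Compound 3 thus stands exactly where the whole set sits, because of the limit of > 20000 nM in this assay, at which 3 of the 3 values shown sit. Compound 4 `COC(=O)CNC(=O)c1c(NO)cc(-c2ccc(OC)cc2)oc1=O` differs from compound 3 by methoxy in place of fluoro on an aromatic carbon. Among the measured compounds shown here, no measured step bears on this change: the step from compound 1 to compound 2 touches the amide-type nitrogen, not the six-membered aromatic ring of carbon only. With every value at the limit, no movement beyond the scatter is expected in this assay. Compound 4 is therefore expected at 25000 nM, between 10000 nM and 60000 nM. The implied step that the limit leaves unreadable from compound 3 to compound 4 is estimated to be flat, most likely reported again only as a limit.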

Compound 4, half-maximal cytotoxic concentration: > 20000 nM
Compound 4: only a limit was reported; the forecaster's own chance of this, stated with the estimate: 85%; the middle value lies beyond the limit too.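

No new step can be read among compound 1, compound 2, compound 3 and compound 4, since all their values are limits: (the limit of > 20000 nM in this assay, at which 4 of the 4 values shown sit). From the compounds shown here alone, whether any change on the shared core gives a value inside the range of the assay stays open.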